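The compounds below may be only part of what the source reports. "The series", "measured", "known", "first", "only" and "open" are said of these compounds alone.

Measured compounds:
- compound 1, `Oc1cccc(-c2cc(-c3cccs3)cc(-c3ccccc3O)n2)c1`: 9300 nM
- compound 2, `Oc1ccc(-c2cc(-c3cccs3)cc(-c3ccccc3O)n2)cc1`: > 50000 nM
- compound 3, `Oc1ccc(-c2cc(-c3ccco3)cc(-c3cccc(O)c3)n2)cc1`: 2070 nM

In a functional assay on DU-145 cells (Homo sapiens) for cytotoxicity, read by CCK-8 assay (a lower number here means a stronger inhibitor, a higher number a weaker inhibitor), compound 1 gives 9300 nM. Compound 2 reaches only the limit of this assay, > 50000 nM, and no number is known for it. The change from compound 1 to compound 2 is 4-hydroxyphenyl in place of 3-hydroxyphenyl on an aromatic carbon, and it brings an at least 5.3-fold higher number from compound 1 to compound 2 (0.73 log units; beyond the scatter); the value of compound 2 is a limit, as the limit of > 50000 nM in this assay, at which 1 of the 3 values shown sits, records. Compound 3 gives 2070 nM in this assay, the lowest of the two numbers; its number lies below that of compound 1, and the gap between the two lies beyond the scatter. The difference between the core of compound 1 and the core of compound 3 is not broken down here.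

Compound 4, `Oc1ccc(-c2cc(-c3ccco3)cc(-c3ccc(O)cc3)n2)cc1`, is not yet measured. It differs from compound 3 by 4-hydroxyphenyl in place of 3-hydroxyphenyl on an aromatic carbon. This is the same kind of change as that from compound 1 to compound 2, though the surroundings of the place differ: in compound 1 the carbon is meta to a 2-hydroxyphenyl group and meta to a thiophen-2-yl group, in compound 3 it is meta to a 4-hydroxyphenyl group and meta to a furan-2-yl group. Resting on the single measured step, an at least 5.3-fold higher number from compound 1 to compound 2 (0.73 log units; beyond the scatter), a weakening of similar size is expected, a 5.8-fold higher number from compound 3 to compound 4 (0.76 log units; beyond the scatter), with wide uncertainty since the earlier step ends at a limit. Compound 4 is therefore estimated at 12000 nM in this assay, within 4000 nM to 50000 nM.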

Compound 4, half-maximal inhibitory concentration: > 50000 nM
Compound 4 gave a limit, no number; the forecaster's own chance of this, stated with the estimate: 20%; middle value at least 4.1-fold (0.61 log units) away from the limit.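

In this assay compound 4 stands at > 50000 nM and this is a limit of the assay, not a number. On these data alone, on this core, 4-hydroxyphenyl in place of 3-hydroxyphenyl brings an at least 24-fold higher number from compound 3 to compound 4 (1.38 log units; beyond the scatter) and counts as a large step whose full size stays open. The change therefore runs the same way on both cores shown, but with only two pairs, each ending at a limit, this fixes a direction and does not show that the size of the step carries from one core to the other: the same change on two cores in this assay, an at least 5.3-fold higher number (0.73 log units; beyond the scatter) from compound 1 to compound 2 and an at least 24-fold higher number (1.38 log units; beyond the scatter) from compound 3 to compound 4; the limit leaves it open whether they differ.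

Still open, as far as these compounds go, is whether the hydroxyl group itself matters at this place, which an unsubstituted phenyl, a 3-methoxyphenyl or a 3-aminophenyl group would test against the 3-hydroxyphenyl group of compound 1 and compound 3. Also open, from the compounds shown here alone, are how furan-2-yl and thiophen-2-yl compare on an otherwise unchanged core and how far compound 2 and compound 4 lie past the end of the measured range, which no comparison here can settle: the limit of > 50000 nM in this assay, at which 2 of the 4 values shown sit.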